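Fluoro for methoxy on the sulfonyl aryl of compound 3

This account rests on a few compounds, and the source may have more. Where it says the series, first, only, none or still open, it means among the compounds named here.

Measured compounds:
compound 1, `COc1ccc(S(=O)(=O)c2cnc3ccc(C)cc3c2N2CCC(C)CC2)cc1`, 62%
compound 2, `COc1ccc(S(=O)(=O)c2cnc3ccc(C)cc3c2N2CCC(C)CC2)cc1Cl`, 93%
compound 3, `COc1ccc(S(=O)(=O)c2cnc3ccc(OC)cc3c2N2CCC(C)CC2)cc1`, 41%

In an assay on isolated protein for displacement of a labelled ligand from metabotropic glutamate receptor 5 (Homo sapiens), with a stated time of 60 min, tested at 1 uM (a lower number here means less inhibition, a higher number more inhibition at the concentration tested (going by the name of the read-out)), compound 3 stands lowest of the three, beneath compound 1 by a number 21 percentage points lower from compound 1 to compound 3 (beyond the scatter) and furthest from compound 2. Compound 4, `COc1ccc2ncc(S(=O)(=O)c3ccc(F)cc3)c(N3CCC(C)CC3)c2c1`, differs from compound 3 by fluoro in place of methoxy on an aromatic carbon. Among the compounds with values here, no measured step swaps these two groups. Within the data shown here, the nearest precedent is a number 31 percentage points higher from compound 1 to compound 2 (beyond the scatter), a halogen entering the same ring, though at another place and alongside the methoxy rather than instead of it. A modest rise is therefore expected, with wide uncertainty: compound 4 is estimated at 50%, between 25% and 75%, an expected step of a number 9 percentage points higher from compound 3 to compound 4 (within the scatter).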

Compound 4, a percentage reported as inhibition, at one concentration (the size of the read-out at that concentration, not a potency): 27%
Beside the measured number, compound 4's estimate is 23 percentage points above it; the range from low to high includes it.
By their numbers in this assay, from the lowest: compound 4; then compound 3; then compound 1; then compound 2.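

In this assay, within the data shown here, the change from 4-methoxyphenyl to 4-fluorophenyl gives a number 14 percentage points lower from compound 3 to compound 4 (beyond the scatter), the first step at this place that replaces the methoxy itself. The earlier halogen step, a number 31 percentage points higher from compound 1 to compound 2 (beyond the scatter), kept the methoxy and put chloro elsewhere on the ring, so a halogen on this ring does not bring a higher number in every case. Nothing available accounts for this fall. Still open, on these data alone, is whether the same exchange on the core of compound 1 would move the number likewise, and how an amine or a hydroxyl at this place would read.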